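Halogen swap on the methylsulfanyl series

The compounds below may be only part of what the source reports. "The series", "measured", "known", "first", "only" and "open" are said of these compounds alone.

Among the compounds with values here, compound 2 `CSc1ccc(F)cc1NCC1=NCCN1` gives 5.62 nM in a functional assay on CHO cells for agonist activity at Alpha-2C adrenergic receptor (Homo sapiens) (a higher number here means that more compound is needed for the effect, a lower number that less compound is needed), the lowest of the two numbers so far; the nearest, compound 1 `CS(=O)(=O)c1ccc(F)cc1NCC1=NCCN1`, gives 2000 nM, and the step of a 360-fold lower number from compound 1 to compound 2 (2.55 log units; beyond the scatter) is the only measured one. Compound 3 `CSc1ccc(Cl)cc1NCC1=NCCN1` differs from compound 2 by chloro in place of fluoro on an aromatic carbon. Within the data shown here, no measured step bears on this change: the one known step concerns methylsulfanyl against methylsulfonyl, not the halogen. The change is therefore expected to give no step beyond the scatter in this assay, that is a 1.1-fold lower number from compound 2 to compound 3 (0.05 log units; within the scatter). Compound 3 is estimated at 5 nM, between 1.5 nM and 20 nM.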

Compound 3, half-maximal effective concentration: 2.82 nM
The estimate for compound 3 lay 1.8-fold (0.25 log units) above the measured number; low and high end bracket the measured number.
By their numbers in this assay, from the lowest: compounds 3 and 2 (each within the scatter of the next); then compound 1.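

In this assay, chloro in place of fluoro on the aromatic carbon para to the methylsulfanyl group gives a 2.0-fold lower number from compound 2 to compound 3 (0.30 log units; within the scatter). Within the data shown here, this is the first measured change at this position, and it shows that, with methylsulfanyl kept, these two halogens cannot be told apart in this assay, whereas a 360-fold lower number from compound 1 to compound 2 (2.55 log units; beyond the scatter) remains the only step beyond the scatter. No measurement available here accounts for this result.

Open, on these data alone, is whether a group other than a halogen, such as an amine, methoxy or nitrile, would give a similar number at this position. Also open, as far as these compounds go, is whether chloro and fluoro would match alongside methylsulfonyl.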